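A few compounds are considered here, and "the series" means these few. Any claim that something is new, unique, unknown or untested is made for them only; others in the source may bear on it.

Measured compounds:
Compound 1, `CC(C)S(=O)(=O)OC1CCC(CN2CCN(c3cc(=O)c4cc(C(F)(F)F)cc([N+](=O)[O-])c4s3)CC2)CC1`, in an ADME assay on Vero cells (Chlorocebus sabaeus) for cytotoxicity, read by MTT assay, with a stated time of 48 h (a lower number here means a stronger inhibitor, a higher number a weaker inhibitor), gives > 64 ug/mL, a limit of the assay.
Compound 2, `O=C(OC1CCC(CN2CCN(c3cc(=O)c4cc(C(F)(F)F)cc([N+](=O)[O-])c4s3)CC2)CC1)C1CCC1`, in this assay gives > 64 ug/mL, likewise a limit.

Within the data shown here, compound 2 therefore stands only at a limit, not at a number, and the one other measured value is a limit as well. Among the measured compounds shown here, the single measured step between the two, a step that the two limits leave unreadable from compound 1 to compound 2, cannot be read in size for that reason, as the limit of > 64 ug/mL in this assay, at which 2 of the 2 values shown sit, records. Compound 3, `O=C(OC1CCC(CN2CCN(c3cc(=O)c4cc(C(F)(F)F)cc([N+](=O)[O-])c4s3)CC2)CC1)c1ccc(C(F)(F)F)cc1`, differs from compound 2 by 4-(trifluoromethyl)phenyl in place of cyclobutyl on a carbonyl carbon. For the measured compounds named here, no measured step of readable size bears on this change; the only step available is unreadable. There is thus no ground for expecting a shift in either direction beyond the scatter in this assay, and the most that can be said is that compound 3 is expected to sit where compound 2 sits. Compound 3 is expected near 64 ug/mL, with a range from 32 ug/mL to 128 ug/mL. That expectation amounts to a step of a number no higher from compound 2 to compound 3 (the limit leaves the size open), which is to say none that the assay would register as a number.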

Compound 3, half-maximal inhibitory concentration: > 64 ug/mL
Compound 3: no number, only a limit; the forecaster's own chance of this, stated with the estimate: 75%; the middle value lies on the limit itself.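

Compound 3 gives only a limit in this assay, not a number, so the steps that link compound 1, compound 2 and compound 3 cannot be read in size: the limit of > 64 ug/mL in this assay, at which 3 of the 3 values shown sit.

The compounds shown leave open how far past that limit each one lies, and whether exchanging these groups changes the value in this assay at all.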